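The source may hold more compounds than are shown below. What is called first, only, known or untested is meant among the compounds shown, and "the series" means these compounds.

In an ADME assay on MT4 cells (Homo sapiens) for cytotoxicity, read by MTT assay (a lower number here means that less compound is tolerated, a higher number that more compound is tolerated), the measured compounds so far are:
compound 1 `Cc1ccccc1C(=O)N(C(=S)OCCN1C(=O)c2ccccc2C1=O)c1ccc(Cl)cc1` with 21000 nM
compound 2 `O=C1c2ccccc2C(=O)N1CCOC(=S)N(C(=O)c1ccc(F)c(F)c1)c1ccc(Cl)cc1` with 52000 nM

Compound 2 holds the higher of these two numbers, so more of it is tolerated than of compound 1 in this test. The next compound is compound 3 `O=C1c2ccccc2C(=O)N1CCOC(=S)N(C(=O)c1cc(F)cc(F)c1)c1ccc(Cl)cc1` and it has not been measured yet. Its difference from compound 2 is 3,5-difluorophenyl in place of 3,4-difluorophenyl on a carbonyl carbon and it amounts to 3,5-difluorophenyl in place of 3,4-difluorophenyl on a carbonyl carbon. The two have the same atoms, joined differently.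

For the measured compounds named here, only one measured step bears on this change. It is a 2.5-fold higher number from compound 1 to compound 2 (0.39 log units; beyond the scatter) and it altered the group on that same carbonyl carbon. That step was modest even though a 2-methylphenyl group gave way to 3,4-difluorophenyl. Going by the values given here, this is thin evidence, as no measured compound carries 3,5-difluorophenyl. Even so, no step beyond the scatter is expected in this assay for this smaller swap. The estimated change is a 1.2-fold lower number from compound 2 to compound 3 (0.06 log units; within the scatter) and it is expected to be slight. For compound 3 the estimate is 45000 nM with an expected range from 20000 nM to 100000 nM in this test.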

Compound 3, half-maximal cytotoxic concentration: 59000 nM
Compound 3: the middle estimate sits 1.3-fold (0.12 log units) below what was measured; the measured number falls inside the stated range.
By their numbers in this assay, from the lowest: compound 1; then compounds 2 and 3 (each within the scatter of the next).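

In this assay, replacing 3,4-difluorophenyl with 3,5-difluorophenyl on the carbonyl carbon gives a 1.1-fold higher number from compound 2 to compound 3 (0.05 log units; within the scatter) and so leaves the tolerated concentration unchanged within the scatter, even though the two groups have the same atoms joined differently. The comparison with the 2-methylphenyl group now rests on two difluorophenyl groups rather than one, since a 2.8-fold higher number from compound 1 to compound 3 (0.45 log units; beyond the scatter) is beyond the scatter, as is a 2.5-fold higher number from compound 1 to compound 2 (0.39 log units; beyond the scatter) in the earlier comparison. No supporting measurement is available to explain either the shared result of the two difluorophenyl groups or their gap from the 2-methylphenyl group.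

The compounds shown leave open how a plain phenyl group, a methoxyphenyl group or a pyridine ring would behave on this carbonyl carbon, and so whether the fluorine atoms themselves matter in this comparison. They also leave open whether the close match between the two difluorophenyl groups would persist if another part of the shared core were changed, as all three compounds differ only in the group on this carbonyl carbon.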